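Allyl Thioether Gives Way to an Arylamide on the Shared Core

The source may report more compounds than this note shows. Statements on the series, on what has been measured and on what is new or still open speak of the compounds shown alone.

Among the compounds with values here, compound 1 `C=CCSc1nc(-c2ccc(C)cc2)nc2ccc(Cl)cc12` gives 9.66 ug/mL in a functional assay on HeLa cells (Homo sapiens) for antiproliferative activity, read by MTT assay, with a stated time of 48 h (on this read-out lower numbers stand for stronger inhibition and higher numbers for weaker inhibition), and stands as the higher of the two numbers measured so far, though within the scatter of compound 2 `Cc1ccc(-c2nc(Sc3ncccc3[N+](=O)[O-])c3cc(Cl)ccc3n2)cc1`, which gives 5.39 ug/mL. Within the data shown here, the only measured step, a 1.8-fold lower number from compound 1 to compound 2 (0.25 log units; within the scatter), replaces allyl on a sulfur with 3-nitropyridin-2-yl. Compound 3 `Cc1ccc(NC(=O)CSc2nc(-c3ccc(C)cc3)nc3ccc(Cl)cc23)cc1` carries a larger change: (4-methylphenyl)carbamoyl in place of vinyl on a saturated chain carbon bound to a sulfur. Among the measured compounds shown here, no measured step covers an amide entering here, so only a small step is expected, a 1.4-fold lower number from compound 1 to compound 3 (0.14 log units; within the scatter), with a wide range. Compound 3 is therefore estimated at 7 ug/mL, between 2.5 ug/mL and 20 ug/mL.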

Compound 3, half-maximal inhibitory concentration: 12.3 ug/mL
Estimate against measurement, compound 3: 1.8-fold (0.24 log units) below; the measured number falls inside the stated range.
By their numbers in this assay, from the lowest: compounds 2, 1 and 3 (each within the scatter of the next, the first and the last beyond it).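

In this assay, the exchange of vinyl for (4-methylphenyl)carbamoyl on a saturated chain carbon bound to a sulfur gives a 1.3-fold higher number from compound 1 to compound 3 (0.10 log units; within the scatter). The sulfur side chain of the shared core thus accepts an amide and a further aromatic ring with no step beyond the scatter, which the earlier pair, with its 3-nitropyridin-2-yl group, did not show. No available evidence explains this result. From the compounds shown here alone, it remains open whether an amine, a carboxylic acid or a longer chain in place of (4-methylphenyl)carbamoyl would give a step beyond the scatter.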